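This account rests on a few compounds, and the source may have more. Where it says the series, first, only, none or still open, it means among the compounds named here.

Working notes on the series.

The assay is an in vitro functional assay on 1321-N1 cells for agonist activity at P2Y purinoceptor 6 (Homo sapiens); on this read-out lower numbers stand for an effect already at smaller amounts and higher numbers for an effect only at larger amounts of compound. Compound 1, `CCCCCCSc1ccn([C@@H]2O[C@H](COP(=O)(O)OP(=O)(O)O)[C@@H](O)[C@H]2O)c(=O)n1`, gives 4900 nM in this assay. Compound 2, `O=c1ccn([C@@H]2O[C@@]3(COP(=O)(O)OP(=O)(O)O)C[C@H]3[C@H]2O)c(=O)[nH]1`, gives 3500 nM in this assay. Going by the values given here, of the two numbers measured so far, compound 1 has the higher one, but its gap to compound 2 lies within the usual scatter, so the two values are read as equivalent and no order is drawn between them. Among the compounds with values here, compound 2 differs from compound 1 in more than one place, so no single step can be taken from that pair.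

Compound 3, `CCSc1ccn([C@@H]2O[C@H](COP(=O)(O)OP(=O)(O)O)[C@@H](O)[C@H]2O)c(=O)n1`, has not been measured. It differs from compound 1 by hydrogen in place of butyl on a saturated chain carbon, two bonds along the chain from a sulfur. Within the data shown here, no measured pair isolates this change, so its size cannot be read from the data. The expectation is a modest move toward a lower number, a 3.3-fold lower number from compound 1 to compound 3 (0.51 log units; beyond the scatter), though a result within the scatter of compound 1 is not excluded. For compound 3 the estimate in this assay is 1500 nM, with a range from 400 nM to 6000 nM.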

Compound 3, half-maximal effective concentration: 280 nM
Estimate against measurement, compound 3: 5.4-fold (0.73 log units) above; measured number outside the range, below it.
By their numbers in this assay, from the lowest: compound 3; then compounds 2 and 1 (each within the scatter of the next).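

Hexylsulfanyl to ethylsulfanyl is the first single change in the series that can be read, and in this assay it gives an 18-fold lower number from compound 1 to compound 3 (1.24 log units; beyond the scatter), a large step. The read-out therefore responds strongly to the chain at this position: removing butyl from the saturated chain carbon, two bonds along the chain from the sulfur, takes the series to compound 3 at 280 nM, a move that the earlier values could not reveal. Nothing measured here bears on the reason for a step of this size.

On these data alone, only the hexyl and ethyl chains can be compared, so it remains open whether the number falls steadily with shortening, passes through a minimum at an intermediate propyl or butyl chain, or falls further with methyl in place of ethyl. As far as these compounds go, it is also open whether the lower number is confined to plain alkyl chains, since a benzyl group, or a short chain ending in an amine or a carboxylic acid, in place of the ethyl of ethylsulfanyl could read quite differently.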